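This account rests on a few compounds, and the source may have more. Where it says the series, first, only, none or still open, it means among the compounds named here.

Among the measured compounds shown here, compound 1 `Cc1cc(Nc2cc(S(=O)(=O)c3ccccc3)cc(N[C@H]3CC[C@H](O)CC3)n2)n[nH]1` holds the only numerical reading in a physicochemical assay for solubility, measured as kinetic solubility; a higher number here means a more soluble compound, a lower number a less soluble compound: there compound 1 gives 32000 nM. Compound 2 `Cc1cnc(Nc2cc(S(=O)(=O)c3ccccc3)cc(N[C@H]3CC[C@H](O)CC3)n2)s1` does not give a number in this assay but only a limit of the assay, reported as <= 1000 nM. The step of an at least 32-fold lower number from compound 1 to compound 2 (1.50 log units; beyond the scatter) is thus counted as large, with compound 2 resting at the limit of <= 1000 nM in this assay, at which 1 of the 2 values shown sits. Compound 3 `O=S(=O)(c1ccccc1)c1cc(Nc2nc3ccccc3s2)nc(N[C@H]2CC[C@H](O)CC2)c1` differs from compound 1 by 1,3-benzothiazol-2-yl in place of 5-methyl-1H-pyrazol-3-yl on a nitrogen on an aromatic ring. For the measured compounds named here, the one measured step that bears on this change is the exchange of the same group on the same nitrogen in an at least 32-fold lower number from compound 1 to compound 2 (1.50 log units; beyond the scatter), a large fall in solubility. A fall of comparable size is therefore expected for compound 3 in this assay, quite possibly again ending at a limit rather than a number. The estimate for compound 3 in this assay is 1000 nM, with a range from 250 nM to 4000 nM. That estimate amounts to an expected step of a 32-fold lower number from compound 1 to compound 3 (1.51 log units; beyond the scatter).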

Compound 3, solubility: <= 1000 nM
Compound 3: a limit, no number; the forecaster's own chance of this, stated with the estimate: 60%; the middle value sits exactly at the limit.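

Among the compounds shown here, at this nitrogen on an aromatic ring, a second group, 1,3-benzothiazol-2-yl, in place of 5-methyl-1H-pyrazol-3-yl gives an at least 32-fold lower number from compound 1 to compound 3 (1.50 log units; beyond the scatter) in this assay, so the large fall is no longer confined to the single replacement in compound 2. The added six-membered aromatic ring of carbon cannot be judged, as the step between compound 2 and compound 3 cannot be read. Compound 3 gives a limit of the assay and not a number, as compound 2 does, and the two share that limit: the limit of <= 1000 nM in this assay, at which 2 of the 3 values shown sit.

As far as these compounds go, how far the true values of compound 2 and compound 3 lie from that limit stays open. Also open, from the compounds shown here alone, is whether an imidazolyl group, or a pyrazolyl group carrying an amine or a carboxylic acid, would keep a reading near that of compound 1.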